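Replacing an amide with a benzylic alcohol on a shared core

A few compounds are considered here, and "the series" means these few. Any claim that something is new, unique, unknown or untested is made for them only; others in the source may bear on it.

Compound 1 `CCN(CC)C(=O)c1ccc(NC(=O)C(C)(O)C(F)(F)F)cc1` shows > 30000 nM in an assay on a protein complex (Cavia porcellus) with sulfonylurea receptors; K-ATP channels (Homo sapiens) as the target (on this read-out higher numbers stand for weaker inhibition and lower numbers for stronger inhibition), which is a limit of the assay and not a number. Compound 2 `CC(O)(C(=O)Nc1ccc(S(=O)(=O)N2CCNCC2)cc1)C(F)(F)F` shows > 30000 nM in this assay, again a limit. Compound 3 `CC(O)(C(=O)Nc1ccc(S(=O)(=O)N2CCOCC2)cc1)C(F)(F)F` shows 5850 nM in this assay.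

Compound 1 thus sits at the limit of > 30000 nM in this assay, at which 2 of the 3 values shown sit, so its own position is known only as a limit. For the measured compounds named here, the only measured step, an at least 5.1-fold lower number from compound 2 to compound 3 (0.70 log units; beyond the scatter), concerns a different part of the shared core and does not touch the group changed here. The unmeasured compound 4 `CC(O)(C(=O)Nc1ccc([C@@H](O)c2ccccc2)cc1)C(F)(F)F` differs from compound 1 in one place: hydroxy(phenyl)methyl in place of diethylcarbamoyl on an aromatic carbon. Going by the values given here, no measured step bears on this change, so there is no basis from the data for expecting a step of a particular size or direction beyond the scatter. As a working estimate, compound 4 is expected to give 15000 nM in this assay, within 3000 nM to 60000 nM, which is an expected step of an at least 2.0-fold lower number from compound 1 to compound 4 (0.30 log units; that floor lies within the scatter), with a real chance that only a limit is reported.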

Compound 4, half-maximal inhibitory concentration: > 30000 nM
Compound 4: only a limit was reported; the forecaster's own chance of this, stated with the estimate: 45%; middle value at least 2.0-fold (0.30 log units) from the limit.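

For the compounds shown here, compound 1 and compound 4 both stand only as limits in this assay, so no step between them can be read: the limit of > 30000 nM in this assay, at which 3 of the 4 values shown sit. The compounds shown leave open whether hydroxy(phenyl)methyl in place of diethylcarbamoyl on an aromatic carbon changes the read-out at all.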